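The source may hold more compounds than are shown below. What is called first, only, known or untested is meant among the compounds shown, and "the series" means these compounds.

The measured compounds:
compound 1, `COc1ccc(C2CC(c3ccc(OCc4cn(Cc5ccc([N+](=O)[O-])cc5)nn4)cc3)=NN2C(C)=O)cc1`, 37%
compound 2, `COc1cc(C2CC(c3ccccc3)=NN2C(C)=O)ccc1OCc1cn(Cc2ccc([N+](=O)[O-])cc2)nn1`, 11%
compound 3, `COc1ccc(C2=NN(C(C)=O)C(c3ccc(OCc4cn(Cc5ccc([N+](=O)[O-])cc5)nn4)c(OC)c3)C2)cc1`, 75%

In a functional assay on COLO 205 cells (Homo sapiens) for inhibition, read by sulforhodamine B assay, tested at 100 uM (a higher number here means more inhibition of growth at the concentration tested, a lower number less inhibition of growth), compound 3 gives 75%, compound 1 gives 37% and compound 2 gives 11%. The difference between the cores of compound 1 and compound 2 is not broken down here. From compound 2 to compound 3 the change is methoxy in place of hydrogen on an aromatic carbon, and it made a step of a number 64 percentage points higher from compound 2 to compound 3 (beyond the scatter).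

Compound 4, `COc1ccc(C2CC(c3ccc(OCc4cn(Cc5ccc([N+](=O)[O-])cc5)nn4)cc3)=NN2C(C)=O)cc1OC`, is not yet measured. It differs from compound 1 by the same kind of change, (methoxy in place of hydrogen on an aromatic carbon); here the entering methoxy sits ortho to a methoxy group and meta to a large group, whereas in the earlier pair it sits para to a large group. Resting on that single earlier step, compound 4 is expected to rise by a number 28 percentage points higher from compound 1 to compound 4 (beyond the scatter) in this assay, with the differing surroundings kept in mind. The estimate for compound 4 is 65%, between 35% and 90%.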

Compound 4, percent growth inhibition at one concentration: 38%
Compound 4: middle estimate off by 27 percentage points, on the high side; the range from low to high includes it.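

In this assay the entering methoxy, in the change from 4-methoxyphenyl to 3,4-dimethoxyphenyl, gave a number 1 percentage points higher from compound 1 to compound 4 (within the scatter), so on this core it left growth inhibition unchanged. The change therefore did not carry over from one core to the other: the same change on two cores in this assay, a number 64 percentage points higher (beyond the scatter) from compound 2 to compound 3 and a number 1 percentage points higher (within the scatter) from compound 1 to compound 4, 63 percentage points apart, beyond the scatter of two such steps

Two pairs do not show whether the core or the place of the entering methoxy decides the outcome, and they give no rule for any further core. The compounds shown leave open whether a hydroxyl, an amine or a longer chain such as ethoxy at that same place on compound 1 would alter the result. Also open, on these data alone, is what a carboxylic acid in place of the nitro group would do.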